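This account rests on a few compounds, and the source may have more. Where it says the series, first, only, none or still open, it means among the compounds named here.

Of the compounds shown here, three with a shared core have been tested in a functional assay on MES-SA cells (Homo sapiens) for inhibition, with a stated time of 72 h; on this read-out lower numbers stand for stronger inhibition and higher numbers for weaker inhibition: compound 1 `Oc1c(CN2CCCCC2)ccc2cccnc12` gives 5210 nM; 5130 nM (2 entries), compound 2 `Oc1c(C(c2cccnc2)N2CCCCC2)ccc2cccnc12` gives 13500 nM, and compound 3 `Oc1c(C(c2cccs2)N2CCCCC2)ccc2cccnc12` gives 8910 nM. Compound 3 has the lower number of the two compounds with a single reading, but that gap lies within the scatter: a 1.5-fold lower number from compound 2 to compound 3 (0.18 log units; within the scatter). This step exchanges pyridin-3-yl for thiophen-2-yl on a saturated chain carbon bound to an amine nitrogen in a ring and an aromatic carbon.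

Compound 4 `Oc1c(C(c2ccncc2)N2CCCCC2)ccc2cccnc12` changes the same carbon: pyridin-4-yl in place of thiophen-2-yl on a saturated chain carbon bound to an amine nitrogen in a ring and an aromatic carbon. The measured step is the only one that bears on this change, and it stays within the scatter. Compound 2 also carries a pyridine group there, with its nitrogen placed differently, and gives 13500 nM. A clear shift in this assay is therefore not expected, only a slight drift toward weaker inhibition. The estimated change, a 1.2-fold higher number from compound 3 to compound 4 (0.09 log units; within the scatter), is expected to remain within the scatter. For compound 4 the expected value is 11000 nM, with an estimated range of 5500 nM to 22000 nM.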

Compound 4, half-maximal inhibitory concentration: 15500 nM
The estimate for compound 4 lay 1.4-fold (0.15 log units) below the measured number, within the range that was stated.
By their numbers in this assay, from the lowest: compounds 3, 2 and 4 (each within the scatter of the next).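

All three aromatic groups seen on the saturated chain carbon bound to an amine nitrogen in a ring and an aromatic carbon now lie within the scatter of one another in this assay and no clear preference among them appears. Exchanging thiophen-2-yl for pyridin-4-yl changes the ring from five-membered to six-membered and the hetero atom from sulfur to nitrogen, yet the step, a 1.7-fold higher number from compound 3 to compound 4 (0.24 log units; within the scatter), stays within the scatter. Placing the pyridine nitrogen differently gives a 1.1-fold higher number from compound 2 to compound 4 (0.06 log units; within the scatter) and so the two pyridine groups cannot be told apart on this read-out.

From the compounds shown here alone, whether a different kind of group on this carbon, such as a carboxylic acid or a longer chain, would give a step beyond the scatter stays open. Nothing measured here accounts for these small differences.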